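A few compounds are considered here, and "the series" means these few. Any claim that something is new, unique, unknown or untested is made for them only; others in the source may bear on it.

Compound 1 `C=C(C)[C@@H]1CC=C(Cn2cc(COc3ccccc3C3NC(=O)NC(C)=C3C(=O)OCC)nn2)CC1` was tested in a functional assay on HT-29 cells (Homo sapiens) for inhibition, read by sulforhodamine B assay, with a stated time of 48 h (on this read-out lower numbers stand for stronger inhibition of growth and higher numbers for weaker inhibition of growth), and gives only a limit there, > 100000 nM, not a number. Compound 2 `C=C(C)[C@@H]1CC=C(Cn2cc(COc3ccc(C4NC(=O)NC(C)=C4C(=O)OCC)cc3OC)nn2)CC1` also reaches only a limit in this assay, > 100000 nM. Compound 1 therefore stands at the limit of > 100000 nM in this assay, at which 2 of the 2 values shown sit, with no measured number to place it against any other compound. Compound 3 `C=C(C)[C@@H]1CC=C(Cn2cc(COc3ccccc3C3NC(=O)NC(C)=C3C(C)=O)nn2)CC1` differs from compound 1 in one place: methyl in place of ethoxy on a carbonyl carbon. Among the measured compounds shown here, no step between two measured compounds exists to size such a change. The step of a number no higher from compound 1 to compound 3 (the limit leaves the size open) is expected to be none beyond the scatter. Compound 3 is estimated at 100000 nM in this assay, between 30000 nM and 300000 nM, most likely again reported only as a limit.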

Compound 3, concentration for total growth inhibition: 79600 nM
Estimate against measurement, compound 3: 1.3-fold (0.10 log units) above, within the range that was stated.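

With acetyl in place of ethoxycarbonyl, this assay returns an actual number for compound 3, 79600 nM. Compound 1 and compound 2 stay at a limit rather than a number: the limit of > 100000 nM in this assay, at which 2 of the 3 values shown sit. The change gives an at least 1.2-fold lower number from compound 1 to compound 3 (0.09 log units; that floor lies within the scatter), so the limit on compound 1 leaves the true size of this step unknown.

The compounds shown leave open whether a carboxylic acid or an amide on this carbonyl carbon would move the number further. They also leave open whether acetyl would have a similar effect on compound 2.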